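Swapping cyano for chloro in a small series

The source may report more compounds than this note shows. Statements on the series, on what has been measured and on what is new or still open speak of the compounds shown alone.

- compound 1 `CS(=O)(=O)c1ccc(-c2nc3ccccn3c2Sc2ccccc2)cc1` gives 13200 nM
- compound 2 `CSc1ccc(-c2nc3ccccn3c2Sc2ccccc2)cc1` gives 7600 nM
- compound 3 `N#Cc1ccc(-c2nc3ccccn3c2Sc2ccccc2)cc1` gives 15700 nM

These three compounds share one core and differ only in a single group, and all were tested in a functional assay on HepG2 cells (Homo sapiens) for inhibition, read by MTT assay, with a stated time of 48 h; on this read-out lower numbers stand for stronger inhibition and higher numbers for weaker inhibition. Compound 3, which carries the cyano group, cannot be told apart from compound 1, as a 1.2-fold higher number from compound 1 to compound 3 (0.08 log units; within the scatter) shows. The gap to compound 2 is only just larger than the usual scatter: a 2.1-fold higher number from compound 2 to compound 3 (0.32 log units; beyond the scatter). Compound 3 therefore sits at the high end of this small set, level with compound 1.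

The next compound is compound 4 `Clc1ccc(-c2nc3ccccn3c2Sc2ccccc2)cc1`, which has chloro in place of cyano on an aromatic carbon. Within the data shown here, no measured compound carries chloro, so the guidance is indirect. The largest measured swap at this place, a 2.1-fold higher number from compound 2 to compound 3 (0.32 log units; beyond the scatter), was modest, and a 1.7-fold lower number from compound 1 to compound 2 (0.24 log units; within the scatter) stayed within the scatter. A small step is therefore expected here too, with only a weak lean towards the middle of the three measured numbers. The expected move is a 1.4-fold lower number from compound 3 to compound 4 (0.15 log units; within the scatter). For compound 4 the estimated value is 11000 nM, with an expected range from 5500 nM to 22000 nM.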

Compound 4, half-maximal inhibitory concentration: 13900 nM
Estimate against measurement, compound 4: 1.3-fold (0.10 log units) below; measured number inside the range.
By their numbers in this assay, from the lowest: compounds 2, 1, 4 and 3 (each within the scatter of the next, the first and the last beyond it).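

In this assay, putting chloro in place of cyano removes the triple bond and the hydrogen-bond acceptor counted for cyano, yet the result is only a 1.1-fold lower number from compound 3 to compound 4 (0.05 log units; within the scatter). Compound 4 also stays within the scatter of the two sulfur-bearing compounds, at a 1.1-fold higher number from compound 1 to compound 4 (0.02 log units; within the scatter) and a 1.8-fold higher number from compound 2 to compound 4 (0.26 log units; within the scatter), so it falls into no separate group and the single gap beyond the scatter, between compound 2 and compound 3, is now bridged by a compound that cannot be told apart from either. No measurement available here accounts for why these four groups read so alike.

From the compounds shown here alone, whether an amine, a carboxylic acid or a longer chain at this place on the aromatic ring would give a number clearly outside this narrow band remains open. Going by these compounds, all four compounds also share the same core and the same phenylsulfanyl part, so it is equally open whether these swaps would stay this small with a different group in place of that phenyl ring.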